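Swapping a Sulfur-Linked Ester for Propargyloxy

A few compounds are considered here, and "the series" means these few. Any claim that something is new, unique, unknown or untested is made for them only; others in the source may bear on it.

Compound 1 `S=c1n(-c2ccc(Cl)cc2)c(=S)n2n1CCCC2`: 61.7 nM
Compound 2 `COC(=O)CSc1cc(/N=c2\sc(=S)n3n2CCCC3)c(F)cc1Cl`: 245 nM

Of the compounds shown here, two with a shared core have been tested in a functional assay on the whole organism for inhibition, with Scenedesmus acutus as the target; a lower number here means a stronger inhibitor, a higher number a weaker inhibitor. Compound 1 gives 61.7 nM, while compound 2 gives 245 nM; of the two, compound 2 carries the higher number, and the gap to compound 1 is beyond the usual scatter. Compound 3 `C#CCOc1cc(/N=c2\sc(=S)n3n2CCCC3)c(F)cc1Cl` has not been measured yet. It differs from compound 2 in one place: propargyloxy in place of ((methoxycarbonyl)methyl)sulfanyl on an aromatic carbon. For the measured compounds named here, no measured pair shows this change, so its effect is unknown. For compound 3 the expected step is small, a 1.2-fold lower number from compound 2 to compound 3 (0.09 log units; within the scatter), probably within the scatter. Compound 3 is estimated at 200 nM, with a range from 70 nM to 600 nM.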

Compound 3, half-maximal inhibitory concentration: 7.24 nM
Compound 3: the middle estimate sits 28-fold (1.44 log units) above what was measured, and the stated range ends above it.
By their numbers in this assay, from the lowest: compound 3; then compound 1; then compound 2.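

In this assay, this aromatic carbon, ortho to the chloro group and para to the fluoro group, proves highly sensitive to what it carries: propargyloxy in place of ((methoxycarbonyl)methyl)sulfanyl gives a 34-fold lower number from compound 2 to compound 3 (1.53 log units; beyond the scatter). A change at this single place can therefore shift inhibition far beyond the scatter. Nothing available explains why this swap has so large an effect. Still open, as far as these compounds go, is whether the gain follows the triple bond, the oxygen link or the loss of the ester. A propoxy chain or a sulfur-linked propargyl group on the same carbon would help separate these.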